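This account rests on a few compounds, and the source may have more. Where it says the series, first, only, none or still open, it means among the compounds named here.

Among the compounds with values here, compound 2 `Cc1nc2c3ccccc3ccc2c2nc3c(ccc4ccccc43)c(-c3cccc4ccccc34)c12` gives the highest of the two numbers recorded in a functional assay on HCT-116 cells (Homo sapiens) for cytotoxicity, read by MTT assay, with a stated time of 48 h (a lower number here means a stronger inhibitor, a higher number a weaker inhibitor), where compound 2 gives 20800 nM; its only neighbour, compound 1 `Cc1nc2c3ccccc3ccc2c2nc3c(ccc4ccccc43)c(-c3nccnc3N)c12`, gives 3560 nM. Within the data shown here, the one step available, a 5.8-fold higher number from compound 1 to compound 2 (0.77 log units; beyond the scatter), came with the swap of the aminopyrazinyl group for naphthalenyl. Compound 3 `Cc1nc2c3ccccc3ccc2c2nc3c(ccc4ccccc43)c(-c3ccccc3S)c12` undoes that group again: 2-sulfanylphenyl in place of naphthalen-1-yl on an aromatic carbon. Among the measured compounds shown here, the entering group returns a donor and an acceptor, so compound 3 is expected to move back part of the way, a 2.3-fold lower number from compound 2 to compound 3 (0.36 log units; beyond the scatter), though no measured step covers this exact change. Compound 3 is therefore estimated at 9000 nM, with a range of 3000 nM to 27000 nM.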

Compound 3, half-maximal inhibitory concentration: 1420 nM
For compound 3 the middle estimate is 6.3-fold (0.80 log units) above the measured one; measured number below the stated range.
By their numbers in this assay, from the lowest: compound 3; then compound 1; then compound 2.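

The position opposite the ring nitrogen proved more sensitive in this assay than the first pair showed: 2-sulfanylphenyl in place of naphthalen-1-yl gave a large step (a 15-fold lower number from compound 2 to compound 3 (1.17 log units; beyond the scatter)). The same group also improved on 3-aminopyrazin-2-yl (a 2.5-fold lower number from compound 1 to compound 3 (0.40 log units; beyond the scatter)), making compound 3 the strongest of the three, with one aromatic ring of carbon only. Nothing available explains either step. The compounds shown leave open whether the sulfanyl group itself matters, and how plain phenyl, or phenyl carrying a hydroxyl or an amine, would compare.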